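From 4-methoxyphenyl to thiophen-2-yl: compound 3 to compound 4

A few compounds are considered here, and "the series" means these few. Any claim that something is new, unique, unknown or untested is made for them only; others in the source may bear on it.

Compound 1 `S=C(NCc1cccnc1)SCCc1nnn[nH]1` gives only a limit in a functional assay on MDA-MB-468 cells (Homo sapiens) for cytotoxicity, read by resazurin assay, with a stated time of 72 h (on this read-out lower numbers stand for stronger inhibition and higher numbers for weaker inhibition), > 100000 nM. Compound 2 `S=C(NCc1cccnc1)SCCc1nc2ccccc2s1` reads 9710 nM and compound 3 `COc1ccc(-c2nnc(CCSC(=S)NCc3cccnc3)o2)cc1` reads 5220 nM. These two values lie within the scatter of each other, so compound 3 shares the measurable end of this small set with compound 2.

Compound 4 `S=C(NCc1cccnc1)SCCc1nnc(-c2cccs2)o1` carries thiophen-2-yl in place of 4-methoxyphenyl on an aromatic carbon of the five-membered aromatic ring with 2 nitrogen and 1 oxygen: thiophen-2-yl in place of 4-methoxyphenyl on an aromatic carbon. Within the data shown here, no measured pair isolates a change at this place, so the set offers no direct precedent for the size or direction of the step. The expectation therefore stays anchored on compound 3 at 5220 nM, with no shift beyond the scatter foreseen in this assay. The estimated step is a 1.1-fold higher number from compound 3 to compound 4 (0.06 log units; within the scatter), with no firm direction. In this assay the expected value for compound 4 is 6000 nM, with an estimated range of 2500 nM to 15000 nM.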

Compound 4, half-maximal inhibitory concentration: 3410 nM
For compound 4 the middle estimate is 1.8-fold (0.25 log units) above the measured one, within the range that was stated.
By their numbers in this assay, from the lowest: compounds 4, 3 and 2 (each within the scatter of the next, the first and the last beyond it). At a limit, above all of these: compound 1.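

In this assay, among these compounds, the first pair that isolates this position gives a 1.5-fold lower number from compound 3 to compound 4 (0.18 log units; within the scatter) and so shows that the place tolerates this exchange without a shift beyond the scatter. Thiophen-2-yl, one five-membered aromatic ring with 1 hetero atom, takes over from the six-membered aromatic ring of carbon only in 4-methoxyphenyl, so neither that ring nor the oxygen of 4-methoxyphenyl is needed for a value in this range in this pair. Nothing shown explains why the two groups read alike.

Among the compounds shown here, with only two groups compared at this place, the effect of an amine or a carboxylic acid on this aromatic carbon remains open in either direction. Also open, going by these compounds, is whether a longer chain leading to the five-membered ring would change the number.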